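The source may hold more compounds than are shown below. What is called first, only, known or untested is meant among the compounds shown, and "the series" means these compounds.

Measured in a functional assay on T47D cells (Homo sapiens) for inhibition, read by CCK-8 assay, with a stated time of 72 h, tested at 1 uM; on this read-out higher numbers stand for more inhibition of growth at the one concentration tested and lower numbers for less inhibition of growth:
- compound 1 `CN(C)C(=O)c1cc2cnc(Nc3ccc(NC(=O)C4(C(=O)Nc5ccc(F)cc5)CC4)cc3)nc2n1C1CCCC1`: 74.7%
- compound 2 `CN(C)C(=O)c1cc2cnc(Nc3ccc(NC(=O)C4(C(=O)Nc5ccc(Cl)cc5)CC4)cc3)nc2n1C1CCCC1`: 22.8%

Of these two compounds, compound 2 holds the lower number, 22.8%. The next compound, compound 3 `COc1ccc(NC(=O)C2(C(=O)Nc3ccc(Nc4ncc5cc(C(=O)N(C)C)n(C6CCCC6)c5n4)cc3)CC2)cc1`, keeps the rest of compound 2 and differs at one place, on an aromatic carbon para to a large group: methoxy in place of chloro on an aromatic carbon. In words, methoxy stands in place of chloro, giving a 4-methoxyphenyl where compound 2 has a 4-chlorophenyl.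

Going by the values given here, only one measured step bears on this change. At the same place, chloro in place of fluoro gave a number 51.9 percentage points lower from compound 1 to compound 2 (beyond the scatter), a large step. Among the compounds with values here, it shows that a swap here can move the read-out far, yet no methoxy compound has been measured, so the data do not fix the size of the new step. With compound 2 at 22.8% and compound 1 at 74.7%, a moderate rise is expected, probably smaller than that earlier step, with wide uncertainty. The expected step is a number 22.2 percentage points higher from compound 2 to compound 3 (beyond the scatter). The estimate for compound 3 is 45%, with an expected range from 15% to 78%.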

Compound 3, percent growth inhibition at one concentration: 76.4%
Beside the measured number, compound 3's estimate is 31.4 percentage points below it, and the stated range covers the measured number.
By their numbers in this assay, from the lowest: compound 2; then compounds 1 and 3 (each within the scatter of the next).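

In this assay, methoxy in place of chloro on this aromatic carbon gave a number 53.6 percentage points higher from compound 2 to compound 3 (beyond the scatter), so a large step at this position can run upward as well as downward, and the addition of an oxygen and a carbon in place of chlorine is compatible with a high number. Methoxy in place of fluoro gave a number 1.7 percentage points higher from compound 1 to compound 3 (within the scatter), which leaves compound 1 and compound 3 indistinguishable on this read-out; among these three compounds the low number therefore belongs to the chloro compound alone, and the values do not follow a steady trend from fluoro through chloro to methoxy. Nothing measured here explains why chloro stands apart from fluoro and methoxy.

The three compounds leave open whether bromo or trifluoromethyl at this place would give a low number like that of compound 2, or whether hydroxy, an amine or a longer alkoxy chain would give a high one like those of compound 1 and compound 3. With one concentration tested, they also leave open whether compound 1 and compound 3 would remain indistinguishable at other concentrations.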